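Aryl substitution in the series: compound 3 to compound 4

The source may hold more compounds than are shown below. What is called first, only, known or untested is meant among the compounds shown, and "the series" means these compounds.

In a functional assay on Raji cells (Homo sapiens) for cytotoxicity, read by CCK-8 assay, with a stated time of 24 h (a higher number here means a weaker inhibitor, a lower number a stronger inhibitor), compound 2 `C=CC(=O)N1C(=O)CCSc2ccccc21` gives 581000 nM, compound 3 `C=CC(=O)N1C(=O)CC(c2ccccc2)Sc2ccccc21` gives 74100 nM and compound 1 `C=CC(=O)N1C(=O)CC(c2ccc(Br)cc2)Sc2ccccc21` gives 51300 nM. Compound 3 therefore lies within the scatter of compound 1 and well under compound 2.

The next structure is compound 4 `C=CC(=O)N1C(=O)CC(c2ccc(C#N)cc2)Sc2ccccc21`, defined by cyano in place of hydrogen on an aromatic carbon, para to a large group. The same difference can be read as phenyl to 4-cyanophenyl.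

Within the data shown here, the closest precedent is the bromo group of compound 1, and a 1.4-fold higher number from compound 1 to compound 3 (0.16 log units; within the scatter) stays within the scatter. The larger changes, an 11-fold higher number from compound 1 to compound 2 (1.05 log units; beyond the scatter) and a 7.8-fold lower number from compound 2 to compound 3 (0.89 log units; beyond the scatter), involve adding or removing the whole aromatic substituent. Compound 4 retains that substituent, so these steps say little about the present change, beyond showing that it matters to have one there. Among the measured compounds shown here, no cyano compound has been measured yet, and a single substituent pair is thin support.

The step expected is a 1.2-fold lower number from compound 3 to compound 4 (0.08 log units; within the scatter), an estimate that stays within the scatter. Compound 4 is expected at 62000 nM, with an estimated range from 30000 nM to 125000 nM.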

Compound 4, half-maximal inhibitory concentration: 84500 nM
Compound 4: middle estimate off by 1.4-fold (0.13 log units), on the low side; measured number inside the range.
By their numbers in this assay, from the lowest: compounds 1, 3 and 4 (each within the scatter of the next); then compound 2.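

Working notes: in this assay, swapping the hydrogen of compound 3 for cyano on the aromatic carbon, para to a large group, gives no step that can be told from scatter (a 1.1-fold higher number from compound 3 to compound 4 (0.06 log units; within the scatter)), and the same holds for the exchange of bromo for cyano (a 1.6-fold higher number from compound 1 to compound 4 (0.22 log units; within the scatter)), so hydrogen, bromo and cyano now read alike at this place across compounds 1, 3 and 4. The benefit of an aryl group on the saturated ring carbon survives with cyano on that group (a 6.9-fold lower number from compound 2 to compound 4 (0.84 log units; beyond the scatter)), which extends to a second substituted aryl group what compound 1 alone had shown, and none of the three aryl compounds goes against it. Nothing available explains why these three groups read alike or why the aryl group matters.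

Still open, as far as these compounds go, is whether this tolerance reaches further, for instance to an amine, a carboxylic acid or a longer chain such as butyl at the same place on the phenyl ring. Also open, from the compounds shown here alone, is whether the same substituents would read alike elsewhere on that ring, and whether a saturated propanoyl group in place of the acryloyl group of the shared core would move the number.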